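This account rests on a few compounds, and the source may have more. Where it says the series, first, only, none or still open, it means among the compounds named here.

Compound 1 `COc1cc2cc(Oc3ccc(NC(=O)Nc4cccc(C(F)(F)F)c4)cc3)c(C)nc2cc1OC`: 1470 nM
Compound 2 `COc1cc2cc(Oc3ccc(NC(=O)Nc4ccc(Cl)c(C(F)(F)F)c4)cc3)c(C)nc2cc1OC`: 1000 nM

Among the measured compounds shown here, in a functional assay on A549 cells (Homo sapiens) for inhibition, read by sulforhodamine B assay, with a stated time of 48 h (on this read-out lower numbers stand for stronger inhibition of growth and higher numbers for weaker inhibition of growth), compound 2 stands lowest of the two numbers, but the only measured step, a 1.5-fold lower number from compound 1 to compound 2 (0.17 log units; within the scatter), lies within the scatter, so the two compounds cannot be set apart. Compound 3 `COc1cc2cc(Oc3ccc(NC(=O)Nc4ccc(Cl)c(Cl)c4)cc3)c(C)nc2cc1OC` differs from compound 2 by chloro in place of trifluoromethyl on an aromatic carbon. For the measured compounds named here, no measured step covers this exchange, and the one step known stayed within the scatter, so for compound 3 a step of no change at the digits printed from compound 2 to compound 3 (within the scatter) is expected, none beyond the scatter. Compound 3 is estimated at 1000 nM, with a range from 400 nM to 2500 nM.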

Compound 3, concentration for 50% growth inhibition: 1640 nM
Compound 3: middle estimate off by 1.6-fold (0.21 log units), on the low side, and the stated range covers the measured number.
By their numbers in this assay, from the lowest: compounds 2, 1 and 3 (each within the scatter of the next).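

In this assay, the exchange of trifluoromethyl for chloro gives a 1.6-fold higher number from compound 2 to compound 3 (0.21 log units; within the scatter), and 3,4-dichlorophenyl in place of 3-(trifluoromethyl)phenyl gives a 1.1-fold higher number from compound 1 to compound 3 (0.05 log units; within the scatter), both within the scatter. So at this position on the aromatic ring, ortho to a chloro group, trifluoromethyl and chloro cannot be told apart on this read-out, and all three compounds remain indistinguishable. No measurement offered here helps to interpret this result. Going by these compounds, whether a nitrile or an amine at this position would move growth inhibition beyond the scatter remains open.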